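The compounds below may be only part of what the source reports. "The series", "measured", "known", "first", "only" and "open" are said of these compounds alone.

Measured set:
- compound 1 `CCCC[S+]([O-])c1sc2nc(-c3nccs3)cc(-c3ccc(C(=O)N(C)C)cc3)c2c1N`: in an assay for inhibition of 15-hydroxyprostaglandin dehydrogenase [NAD(+)] (Homo sapiens), read by fluorescence, with a stated time of 15 min, in the presence of a further agent that is not named here (a lower number here means a stronger inhibitor, a higher number a weaker inhibitor), compound 1 gives 5.9 nM
- compound 2 `CCCC[S+]([O-])c1sc2nc(-c3nccs3)cc(-c3ccc(COC(=O)CN(C)C)cc3)c2c1N`: compound 2 gives 3.5 nM
- compound 3 `CCCC[S+]([O-])c1sc2nc(-c3nccs3)cc(-c3ccc(CNC(=O)NCC)cc3)c2c1N`: compound 3 gives 2.1 nM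

Compound 3 is separated from compound 1 only: a 2.8-fold lower number from compound 1 to compound 3 (0.45 log units; beyond the scatter); compound 2 and compound 3 lie within the scatter of each other: a 1.7-fold lower number from compound 2 to compound 3 (0.22 log units; within the scatter). Compound 4 `CCCC[S+]([O-])c1sc2nc(-c3nccs3)cc(-c3ccc(CNS(C)(=O)=O)cc3)c2c1N` differs from compound 3 at one place: methylsulfonyl in place of ethylcarbamoyl on an amine nitrogen. Among the measured compounds shown here, no measured step covers this exchange. The two steps reaching compound 3 bear on it indirectly, since both rework the substituent on the same aromatic carbon, and they shifted the number in this assay little: one modestly, one within the scatter. A step of a 1.7-fold higher number from compound 3 to compound 4 (0.22 log units; within the scatter) is therefore expected, close to no change. Compound 4 is expected at 3.5 nM, with a range from 1.5 nM to 9 nM.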

Compound 4, half-maximal inhibitory concentration: 4.6 nM
The estimate for compound 4 lay 1.3-fold (0.12 log units) below the measured number, within the range that was stated.
By their numbers in this assay, from the lowest: compounds 3, 2, 4 and 1 (each within the scatter of the next, the first and the last beyond it).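

Among the compounds shown here, at this amine nitrogen in this assay, the exchange of ethylcarbamoyl for methylsulfonyl gives a modest but readable shift, with a 2.2-fold higher number from compound 3 to compound 4 (0.34 log units; beyond the scatter) as the only step taken at the nitrogen itself. Set against the other substituents on the same aromatic carbon, a 1.3-fold higher number from compound 2 to compound 4 (0.12 log units; within the scatter) and a 1.3-fold lower number from compound 1 to compound 4 (0.11 log units; within the scatter) both lie within the scatter, so only compound 3 stands apart from compound 1 and compound 4. No data here account for the shift at this nitrogen.

As far as these compounds go, whether ethylsulfonyl, with its longer chain, or a free amine at this nitrogen would read like compound 3 or like compound 4 stays open.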